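Chloro for methoxy on the oxime-bearing ring of compound 1

The compounds below may be only part of what the source reports. "The series", "measured", "known", "first", "only" and "open" are said of these compounds alone.

Compound 1 `COc1ccc(C(/C=C/c2ccc(Cl)cc2)=N/O)cc1` stands second highest of the three numbers in an ADME assay on cells (Mus musculus, strain Balb/c) for cytotoxicity, read by MTT assay, with a stated time of 48 h (a lower number here means that less compound is tolerated, a higher number that more compound is tolerated), where compound 1 gives 291000 nM. Compound 2 `COc1ccc(C(/C=C/c2ccc(F)cc2)=N/O)cc1` gives 13500 nM in this assay, and compound 3 `COc1ccc(/C=C/C(=N\O)c2ccc(OC)cc2)cc1` gives 2170000 nM. The measured steps are all exchanges on an aromatic carbon: a 22-fold lower number from compound 1 to compound 2 (1.33 log units; beyond the scatter), a 7.5-fold higher number from compound 1 to compound 3 (0.87 log units; beyond the scatter) and a 160-fold higher number from compound 2 to compound 3 (2.21 log units; beyond the scatter).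

Compound 4 `O/N=C(\C=C\c1ccc(Cl)cc1)c1ccc(Cl)cc1` differs from compound 1 as follows: chloro in place of methoxy on an aromatic carbon. Among the compounds with values here, no measured step reproduces this change; the nearest analogy is the exchange of chloro for methoxy, which in the measured direction gave a 7.5-fold higher number from compound 1 to compound 3 (0.87 log units; beyond the scatter). The present change runs the opposite way, chloro entering where methoxy leaves, and it sits on a different part of the shared core, so the analogy is loose. On that basis a lower number than for compound 1 is expected in this assay, of modest size and beyond the scatter, though the direction is uncertain given the scale of the fluoro-for-chloro step a 22-fold lower number from compound 1 to compound 2 (1.33 log units; beyond the scatter). For compound 4 the expected value in this assay is 60000 nM, with a range of 12000 nM to 300000 nM. The step this estimate implies is a 4.9-fold lower number from compound 1 to compound 4 (0.69 log units; beyond the scatter).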

Compound 4, half-maximal cytotoxic concentration: 14100 nM
The estimate for compound 4 lay 4.3-fold (0.63 log units) above the measured number; the measured number falls inside the stated range.
By their numbers in this assay, from the lowest: compounds 2 and 4 (each within the scatter of the next); then compound 1; then compound 3.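

This is the first change shown at the aromatic carbon that carries methoxy in compound 1, para to a large group, a place the earlier steps left untouched. In this assay chloro in place of methoxy here gives a 21-fold lower number from compound 1 to compound 4 (1.31 log units; beyond the scatter) and so shows that this position, too, moves the number strongly, with a step of large size rather than a marginal shift. Read together with a 7.5-fold higher number from compound 1 to compound 3 (0.87 log units; beyond the scatter) at the other substituted position, methoxy goes with the higher number at both places, and none of the compounds shown goes against this, although it rests on only these two exchanges; no measurement on hand accounts for the size or direction of the change.

Open is where a fluoro, a hydroxy or an amine at this position would fall relative to methoxy and chloro, so the two groups shown give only two points at this place. Also open, as far as these compounds go, is whether the two positions act independently, which a pair differing in one place at each position, with fluoro and with methoxy on the other ring, would begin to answer.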